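Permeability of a sulfonyl-piperidine analog in the Caco-2 assay

This account rests on a few compounds, and the source may have more. Where it says the series, first, only, none or still open, it means among the compounds named here.

Measured compounds:
compound 1 `Cn1cncc1CN1CC(N(CC2CCN(C(=O)c3ccc(Cl)cc3)CC2)S(=O)(=O)c2ccccn2)Cc2cc(C#N)ccc21` — 0.5 10^-6 cm/s
compound 2 `Cn1cncc1CN1CC(N(CC2CCN(C(=O)C3CC3)CC2)S(=O)(=O)c2ccccn2)Cc2cc(C#N)ccc21` — 0.5 10^-6 cm/s

Compounds 1 and 2 share a core and differ only at the carbonyl carbon, where compound 2 carries cyclopropyl in place of 4-chlorophenyl. In an ADME assay on Caco-2 cells (Homo sapiens) for permeability, in the apical to basolateral direction (on this read-out lower numbers stand for lower permeability and higher numbers for higher permeability), compound 1 gives 0.5 10^-6 cm/s and compound 2 gives 0.5 10^-6 cm/s; the step of no change at the digits printed from compound 1 to compound 2 (within the scatter). Compound 1 therefore stands level with compound 2 at the digits shown, and both lie at the low end of the read-out.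

Compound 3 `CCS(=O)(=O)N1CCC(CN(C2Cc3cc(C#N)ccc3N(Cc3cncn3C)C2)S(=O)(=O)c2ccccn2)CC1` has not yet been measured in this assay. Relative to compound 1 the change is ethylsulfonyl in place of (4-chlorophenyl)carbonyl on an amine nitrogen in a ring. Going by the values given here, the only measured step, no change at the digits printed from compound 1 to compound 2 (within the scatter), bears on this change as an exchange at the same amine nitrogen, and it was flat. An ethylsulfonyl is a different group from a cyclopropylcarbonyl, so the analogy is loose, but nothing measured points to a move beyond the scatter. The step of no change at the digits printed from compound 1 to compound 3 (within the scatter) is expected to be within the scatter. Compound 3 is estimated at 0.5 10^-6 cm/s, within 0.2 10^-6 cm/s to 1.2 10^-6 cm/s.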

Compound 3, apparent permeability: 0.1 10^-6 cm/s
Beside the measured number, compound 3's estimate is 5.0-fold (0.70 log units) above it; measured number below the stated range.
By their numbers in this assay, from the lowest: compound 3; then compounds 1 and 2 (each within the scatter of the next).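

In this assay, the amine nitrogen in the six-membered non-aromatic ring no longer looks indifferent to its substituent: the exchange between two carbonyl-linked groups was flat, but ethylsulfonyl gives a 5.0-fold lower number from compound 1 to compound 3 (0.70 log units; beyond the scatter) and, set against cyclopropylcarbonyl, a 5.0-fold lower number from compound 2 to compound 3 (0.70 log units; beyond the scatter). The earlier flat step therefore holds only for the pair of carbonyl-linked groups and does not carry over to compound 3, the one compound shown with a sulfonyl at this nitrogen. Nothing in the data accounts for this drop.

Compound 3 differs from compounds 1 and 2 in both the linking group and what it carries, so the compounds shown cannot separate the sulfonyl link from the ethyl group. An ethylcarbonyl or a 4-chlorophenylsulfonyl at the same nitrogen would pull these two apart, while a plain alkyl chain there would test whether any link is needed.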